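Methyl on a Ring Nitrogen Wipes Out Receptor Inhibition

This account rests on a few compounds, and the source may have more. Where it says the series, first, only, none or still open, it means among the compounds named here.

Compound 3 `Clc1ccc(Cl)c(-c2nc(N3CCCCC3)c3nc[nH]c3n2)c1` and compound 2 `Oc1cccc(-c2nc(N3CCCCC3)c3nc[nH]c3n2)c1` carry the same ring framework but differ from each other in more than one place; the difference between the two cores is not broken down here. Compound 1 `Cn1cnc2c(N3CCCCC3)nc(-c3cc(Cl)ccc3Cl)nc21` is compound 3 with a single change, (methyl in place of hydrogen on an aromatic nitrogen).

In an assay on cells for displacement of a labelled ligand from adenosine receptor A3 (Homo sapiens), read by scintillation counting and radioligand binding, with a stated time of 180 min, tested at 10 uM (a higher number here means more inhibition at the concentration tested (going by the name of the read-out), a lower number less inhibition), compound 3 gives > 80%, which is a limit of the assay and not a number. In this assay compound 2 gives > 80%, again a limit rather than a measured number. Compound 1, by contrast, gives 5.4% in this assay. The step of a number at least 74.6 percentage points lower from compound 3 to compound 1 (beyond the scatter) is therefore large, and its true size cannot be pinned down exactly, since the limit of > 80% in this assay, at which 2 of the 3 values shown sit, means the starting point is only known as a limit.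

Compound 4 `Cn1cnc2c(N3CCCCC3)nc(-c3cccc(O)c3)nc21` has not yet been measured. It stands to compound 2 as compound 1 stands to compound 3: the change methyl in place of hydrogen on an aromatic nitrogen is the same change, made at the same place. Since the measured step from compound 3 to compound 1 was a collapse, a similar collapse is expected here, so the step of a number at least 70 percentage points lower from compound 2 to compound 4 (beyond the scatter) is estimated to be of the same kind. Compound 4 is therefore expected to give about 10% in this assay, most likely between 0% and 35%.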

Compound 4, a percentage reported as inhibition, at one concentration (the size of the read-out at that concentration, not a potency): 49.1%
Compound 4: middle estimate off by 39.1 percentage points, on the low side; the measured number lies above the stated range.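

In this assay, methyl in place of hydrogen on an aromatic nitrogen lowers the read-out on the second core as well, and the step is a number at least 30.9 percentage points lower from compound 2 to compound 4 (beyond the scatter), so the direction of the change carries over from the core with 2,5-dichlorophenyl to the core with 3-hydroxyphenyl. With the methyl present on both compounds, the step for 3-hydroxyphenyl in place of 2,5-dichlorophenyl on an aromatic carbon is a number 43.7 percentage points higher from compound 1 to compound 4 (beyond the scatter), so the methylated compound with 3-hydroxyphenyl keeps more of the read-out. Compound 2 and compound 3 are known only as limits of the assay, so what is not shown is whether the change costs the same amount on both cores: the same change on two cores in this assay, a number at least 74.6 percentage points lower (beyond the scatter) from compound 3 to compound 1 and a number at least 30.9 percentage points lower (beyond the scatter) from compound 2 to compound 4; the limit leaves it open whether they differ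

The compounds shown leave open whether a longer chain, such as ethyl, on the same ring nitrogen would lower the read-out as the methyl does, and whether the higher value of compound 4 would survive if an amine or a carboxylic acid replaced the hydroxy group. Also open, from the compounds shown here alone, is how the methyl would behave on a core carrying any other group on that aromatic carbon.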